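This account rests on a few compounds, and the source may have more. Where it says the series, first, only, none or still open, it means among the compounds named here.

In an ADME assay on a cell-free system (plasma, Homo sapiens) for protein binding, compound 1 `C[C@@H](Oc1cc2cnn(CCC(=O)O)c2cc1Cl)c1ccccn1` gives 90.1% and compound 2 `Cc1ccc([C@@H](C)Oc2cc3onc(CCC(=O)O)c3cc2Cl)nc1` gives 99.7% as the second measured value. Compound 2 therefore has the lower unbound fraction of the two, and its gap to compound 1 lies beyond the scatter. Within the data shown here, these two compounds differ in more than one place, so no measured step isolates a single change. Compound 3 `C[C@@H](Oc1cc2onc(CCC(=O)O)c2cc1Cl)c1ccccn1` keeps the core of compound 2 and carries hydrogen in place of methyl on an aromatic carbon, hydrogen in place of methyl on an aromatic carbon, so that 5-methylpyridin-2-yl becomes pyridin-2-yl. The shared core makes compound 2, at 99.7%, the closer reference. A modest shift toward more free compound is expected, slightly beyond the scatter, with an estimated step a 2.7-fold higher unbound fraction from compound 2 to compound 3 (0.43 log units; beyond the scatter) as the working figure. The estimate for compound 3 is an expected 99.2% in this assay, with a range from 97.5% to 99.7% around it.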

Compound 3, plasma protein binding: 97.8%
Estimate against measurement, compound 3: 2.8-fold (0.44 log units) (unbound fraction) below, and the stated range covers the measured number.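

In this assay, among these compounds, replacing the methyl with hydrogen, so that 5-methylpyridin-2-yl becomes pyridin-2-yl, gives a 7.3-fold higher unbound fraction from compound 2 to compound 3 (0.87 log units; beyond the scatter) and is the first step here that isolates a single change. It shows that this position, on an aromatic carbon two atoms from the ring nitrogen and para to a large group, is not silent in this read-out: the loss of one heavy atom, with no net charge involved, moves the unbound fraction beyond the scatter. No measured evidence is available to explain this step.

The compounds shown carry only hydrogen or methyl at this position, so the effect of a fluorine, a methoxy group or a longer chain such as ethyl there remains open. As far as these compounds go, it also remains open whether the same change would shift the read-out similarly on the core of compound 1.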